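Taking the methyl group off compound 3

The source may hold more compounds than are shown below. What is called first, only, known or untested is meant among the compounds shown, and "the series" means these compounds.

Of the compounds shown here, three have been tested so far in a functional assay on the whole organism with Mus musculus as the target; on this read-out higher numbers stand for an effect only at larger amounts of compound and lower numbers for an effect already at smaller amounts. Compound 1 `O=C(/C=C1\CCc2ccccc21)NC1CC1` gives 150 mg/kg. For compound 2 `Cc1cccc2c1CC/C2=C\C(N)=O` the assay reports only a limit, > 100 mg/kg. Compound 3 `Cc1cccc2c1/C(=C/C(N)=O)CC2` gives 82 mg/kg, and this number lies within the usual scatter of the number for compound 1. Within the data shown here, compound 3 therefore stands level with compound 1, and these two are the only true numbers available so far.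

Compound 4 `NC(=O)/C=C1\CCc2ccccc21` has not yet been measured. It differs from compound 3 in a single place: hydrogen in place of methyl on an aromatic carbon. Hydrogen stands in place of methyl on an aromatic carbon. Among the measured compounds shown here, no measured pair of compounds shows this change on its own, so the data give no direct size for it. For the measured compounds named here, the only guide is the narrow spread of the numbers in hand, with compound 1 at 150 mg/kg and compound 3 at 82 mg/kg. No shift beyond the scatter is therefore expected in this assay, in either direction. The estimated change is a 1.2-fold higher number from compound 3 to compound 4 (0.09 log units; within the scatter), which is expected to stay within the scatter. For compound 4 the estimated value is 100 mg/kg, with an expected range from 40 mg/kg to 250 mg/kg.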

Compound 4, dose for half-maximal effect: 108 mg/kg
Estimate against measurement, compound 4: 1.1-fold (0.03 log units) below; measured number inside the range.
By their numbers in this assay, from the lowest: compounds 3, 4 and 1 (each within the scatter of the next).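

In this assay, among these compounds, the step of a 1.3-fold higher number from compound 3 to compound 4 (0.12 log units; within the scatter) gives the first direct reading of hydrogen in place of methyl on this aromatic carbon, and it shows that the methyl group can leave this position without a shift beyond the scatter. The step of a 1.4-fold lower number from compound 1 to compound 4 (0.14 log units; within the scatter), with hydrogen in place of cyclopropyl on the amide-type nitrogen, also stays within the scatter, so neither single change moves the number measurably on the compounds shown. The same methyl-to-hydrogen change starting from compound 2 cannot be read, because compound 2 carries only a limit: the limit of > 100 mg/kg in this assay, at which 1 of the 4 values shown sits.

The compounds shown leave open whether a larger or different group on this aromatic carbon, such as a chlorine atom, a methoxy group or a carboxylic acid, would also stay within the scatter of compound 4 or would move the number clearly. They also leave open whether a longer chain or an amine on the amide-type nitrogen would separate from compound 4 in either direction.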